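This account rests on a few compounds, and the source may have more. Where it says the series, first, only, none or still open, it means among the compounds named here.

Three amides share one pattern: a methoxy-bearing bicyclic core joined through an amide to a benzene ring carrying a single para group. Compound 1 `COc1cccc2sc(NC(=O)c3ccc(C(F)(F)F)cc3)nc12`, compound 2 `COc1cccc2sc(NC(=O)c3ccc([N+](=O)[O-])cc3)nc12` and compound 3 `COc1ccc2sc(NC(=O)c3ccc([N+](=O)[O-])cc3)nc2c1` were tested in a functional assay on NUGC-3 cells (Homo sapiens) for antiproliferative activity, read by sulforhodamine B assay; on this read-out lower numbers stand for stronger inhibition of growth and higher numbers for weaker inhibition of growth. In this assay compound 1 gives only a limit, > 10 ug/mL. Compound 2 likewise gives only a limit, > 10 ug/mL. Compound 3 too gives only a limit, > 10 ug/mL. The change trifluoromethyl in place of nitro on an aromatic carbon therefore yields a step that the two limits leave unreadable from compound 2 to compound 1. The cores of compound 2 and compound 3 differ, but that difference is not broken down here. Compound 4 `COc1ccc2sc(NC(=O)c3ccc(C(F)(F)F)cc3)nc2c1` is not yet measured; it arises from compound 3 by trifluoromethyl in place of nitro on an aromatic carbon, the same change as from compound 2 to compound 1, at the same place. Because (the limit of > 10 ug/mL in this assay, at which 3 of the 3 values shown sit), the expected step is a step that the limit leaves unreadable from compound 3 to compound 4. Compound 4 is thus estimated at 15 ug/mL, and most likely this assay will again report only a limit.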

Compound 4, concentration for 50% growth inhibition: > 10 ug/mL
Compound 4: a limit, no number (the forecaster's own chance of this, stated with the estimate: 80%); the middle value lies beyond the limit too.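

Compound 3 and compound 4 both give only limits, so no step between them can be read: the limit of > 10 ug/mL in this assay, at which 4 of the 4 values shown sit.

The compounds shown leave open whether trifluoromethyl in place of nitro changes growth inhibition at all, on either core.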